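A few compounds are considered here, and "the series" means these few. Any claim that something is new, unique, unknown or untested is made for them only; others in the source may bear on it.

Three spiro compounds have been tested in an assay on membranes from brain for displacement of a labelled ligand from Sigma non-opioid intracellular receptor 1 (Cavia porcellus), read by scintillation counting, with a stated time of 120 min; a lower number here means a stronger inhibitor, a higher number a weaker inhibitor. Compound 1, `c1ccc(CN2CCC3(CC2)OCCc2cc(-c4ccccc4)sc23)cc1`, gives 2.4 nM. Compound 2, `COC1Cc2cc(-c3ccccc3)sc2C2(CCN(Cc3ccccc3)CC2)O1`, gives 16 nM. Compound 3, `c1ccc(CN2CCC3(CC2)OCCc2ccsc23)cc1`, gives 1 nM, the lowest of the three numbers.

Two changes connect them. Removing the phenyl from the aromatic ring of compound 1 gives compound 3; this change is hydrogen in place of phenyl on an aromatic carbon and it made a step of a 2.4-fold lower number from compound 1 to compound 3 (0.38 log units; beyond the scatter). Adding a methoxy to compound 1 gives compound 2; this change is methoxy in place of hydrogen on a saturated ring carbon and it made a step of a 6.7-fold higher number from compound 1 to compound 2 (0.82 log units; beyond the scatter).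

Compound 4, `COC1Cc2ccsc2C2(CCN(Cc3ccccc3)CC2)O1`, has not yet been measured. It arises from compound 3 by methoxy in place of hydrogen on a saturated ring carbon, which is the same change as the one from compound 1 to compound 2, at the same place on the same kind of ring; the two cores differ only by the phenyl described above. Because that earlier step was a 6.7-fold higher number from compound 1 to compound 2 (0.82 log units; beyond the scatter), a similar weakening is expected here: the estimated step is a 6.0-fold higher number from compound 3 to compound 4 (0.78 log units; beyond the scatter). On that basis compound 4 is estimated at 6 nM, most likely between 2.5 nM and 15 nM in this assay.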

Compound 4, inhibition constant: 1.9 nM
Compound 4: the middle estimate sits 3.2-fold (0.50 log units) above what was measured; measured number outside the range, below it.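

In this assay, methoxy in place of hydrogen on the saturated ring carbon, with no phenyl on the core, made a 1.9-fold higher number from compound 3 to compound 4 (0.28 log units; within the scatter), so this change does not carry over at the same size from one core to the other: the same change on two cores in this assay, a 6.7-fold higher number (0.82 log units; beyond the scatter) from compound 1 to compound 2 and a 1.9-fold higher number (0.28 log units; within the scatter) from compound 3 to compound 4, 3.5-fold (0.55 log units) apart, beyond the scatter of two such steps Seen from the other side, with the methoxy present, hydrogen in place of phenyl made an 8.4-fold lower number from compound 2 to compound 4 (0.93 log units; beyond the scatter), and the size of this change also depends on the core: the same change on two cores in this assay, a 2.4-fold lower number (0.38 log units; beyond the scatter) from compound 1 to compound 3 and an 8.4-fold lower number (0.93 log units; beyond the scatter) from compound 2 to compound 4, 3.5-fold (0.55 log units) apart, beyond the scatter of two such steps Both comparisons rest on the same four compounds and so show one dependence between the methoxy and the phenyl, not two separate findings, and they show neither its cause nor whether it holds on any other core.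

As far as these compounds go, it remains open whether another group on that saturated ring carbon, such as hydroxy or ethoxy, would also depend on the core. The same question stands for another group on the aromatic carbon in place of phenyl, such as methyl or chlorine.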